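The source may report more compounds than this note shows. Statements on the series, on what has been measured and on what is new or still open speak of the compounds shown alone.

Measured in a physicochemical assay for lipophilicity, measured as octanol-water partition; a lower number here means a more polar compound, a higher number a more lipophilic compound:
- Compound 1 `O=C(NNc1ccnc2cc(Cl)ccc12)c1ccccc1/N=C/c1ccc(Cl)cc1`: 5.62
- Compound 2 `O=C(NNc1ccnc2cc(Cl)ccc12)c1ccccc1/N=C/c1ccc(O)cc1`: 4.65
- Compound 3 `N#Cc1ccc(/C=N/c2ccccc2C(=O)NNc2ccnc3cc(Cl)ccc23)cc1`: 4.83

Compound 3 stands beneath compound 1, with a number 0.79 log units lower from compound 1 to compound 3 (beyond the scatter). With a number 0.18 log units higher from compound 2 to compound 3 (within the scatter), it cannot be told apart from compound 2. Compound 4 `O=C(NNc1ccnc2cc(Cl)ccc12)c1ccccc1/N=C/C=C/c1ccccc1` follows from compound 3 by 2-phenylethenyl in place of 4-cyanophenyl on a carbon with a double bond to nitrogen, with 2-phenylethenyl in place of 4-cyanophenyl on a carbon with a double bond to nitrogen. Going by the values given here, no measured step covers 2-phenylethenyl. The nearest guide is the change that brought in the cyano group, a number 0.79 log units lower from compound 1 to compound 3 (beyond the scatter). As the 4-cyanophenyl now leaves, a modest upward move of similar size is expected. The expected change is a number 0.67 log units higher from compound 3 to compound 4 (beyond the scatter). Compound 4 is estimated at 5.5, within an expected range of 5 to 6.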

Compound 4, partition coefficient: 5.54
Estimate against measurement, compound 4: 0.04 log units below; the measured number falls inside the stated range.
By their numbers in this assay, from the lowest: compounds 2 and 3 (each within the scatter of the next); then compounds 4 and 1 (each within the scatter of the next).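

In this assay, the step of a number 0.71 log units higher from compound 3 to compound 4 (beyond the scatter) and the step of a number 0.89 log units higher from compound 2 to compound 4 (beyond the scatter) both come with 2-phenylethenyl on the carbon with a double bond to nitrogen, while the step of a number 0.08 log units lower from compound 1 to compound 4 (within the scatter) leaves compound 4 indistinguishable from compound 1. A group other than a substituted phenyl at this place thus reaches the same range as the 4-chlorophenyl group of compound 1. Nothing at hand gives a cause for these steps.

From the compounds shown here alone, whether an amine or a carboxylic acid at this place would shift the number stays open. So does the effect of a longer chain carrying further double bonds.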